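Moving the trifluoromethyl around the pendant phenyl ring

This account rests on a few compounds, and the source may have more. Where it says the series, first, only, none or still open, it means among the compounds named here.

Compound 1, `Oc1cccc(-c2cc(-c3ccc(F)cc3)cc(-c3ccccc3O)n2)c1`: > 50000 nM, a limit of the assay
Compound 2, `Oc1cccc(-c2cc(-c3ccccc3C(F)(F)F)cc(-c3ccccc3O)n2)c1`: 7250 nM
Compound 3, `Oc1cccc(-c2cc(-c3cccc(C(F)(F)F)c3)cc(-c3ccccc3O)n2)c1`: 13000 nM

All three share one core and differ only in the pendant phenyl group. In a functional assay on DU-145 cells (Homo sapiens) for inhibition (a lower number here means a stronger inhibitor, a higher number a weaker inhibitor), compound 1 gives only a limit, > 50000 nM. Compound 2 gives 7250 nM and compound 3 gives 13000 nM; these two sit within the usual scatter of each other, as the step of a 1.8-fold higher number from compound 2 to compound 3 (0.25 log units; within the scatter) shows. Compound 4, `Oc1cccc(-c2cc(-c3ccc(C(F)(F)F)cc3)cc(-c3ccccc3O)n2)c1`, is not yet measured. It differs from compound 3 in one place: 4-(trifluoromethyl)phenyl in place of 3-(trifluoromethyl)phenyl on an aromatic carbon. Within the data shown here, the only measured step of the same kind, shifting the trifluoromethyl between positions, is a 1.8-fold higher number from compound 2 to compound 3 (0.25 log units; within the scatter), which stayed within the scatter. Compound 1, which carries 4-fluorophenyl, gives only a limit in this assay. Compound 4 is therefore expected near 16000 nM, between 6000 nM and 45000 nM, an estimated step of a 1.2-fold higher number from compound 3 to compound 4 (0.09 log units; within the scatter).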

Compound 4, half-maximal inhibitory concentration: > 50000 nM
Compound 4: only a limit was reported; the forecaster's own chance of this, stated with the estimate: 20%; middle value at least 3.1-fold (0.49 log units) away from the limit.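

Where the trifluoromethyl sits on the pendant ring matters after all: in this assay, moving it to give 4-(trifluoromethyl)phenyl produces an at least 3.8-fold higher number from compound 3 to compound 4 (0.58 log units; beyond the scatter) and an at least 6.8-fold higher number from compound 2 to compound 4 (0.83 log units; beyond the scatter). Activity can therefore be read with the 2- and 3-(trifluoromethyl)phenyl groups, but not with the 4-(trifluoromethyl)phenyl group. The step from compound 1 to compound 4 cannot be read, since both values are limits: the limit of > 50000 nM in this assay, at which 2 of the 4 values shown sit.

Going by these compounds, whether any group in this 4-position gives the same result stays open. A 4-methoxyphenyl or 4-aminophenyl group could test this.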